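Same Atoms, Joined Differently: From Compound 3 to Compound 4

The source may report more compounds than this note shows. Statements on the series, on what has been measured and on what is new or still open speak of the compounds shown alone.

Compound 1, `CC(=O)N1CCC(n2cc(-c3cnc(N)c4oc(-c5cnc6cnccn56)cc34)cn2)CC1`, gives 0.52 in an ADME assay on microsomes from liver (Mus musculus) for metabolic stability; on this read-out lower numbers stand for lower hepatic extraction and higher numbers for higher hepatic extraction.
Compound 2, `CC(=O)N1CCC(n2cc(-c3cnc(N)c4oc(-c5cccc6ccccc56)cc34)cn2)CC1`, gives 0.77.
Compound 3, `CC(=O)N1CCC(n2cc(-c3cnc(N)c4oc(-c5cccc6cnsc56)cc34)cn2)CC1`, gives 0.84.

Compound 3 stands highest of the three in this assay; its nearest neighbour is compound 2, a number 0.070 higher from compound 2 to compound 3 (within the scatter), and its furthest is compound 1, a number 0.32 higher from compound 1 to compound 3 (beyond the scatter). Compound 4, `CC(=O)N1CCC(n2cc(-c3cnc(N)c4oc(-c5csc6cnccc56)cc34)cn2)CC1`, has not been measured. It differs from compound 3 by a group of 9 heavy atoms (7 carbon, 1 nitrogen, 1 sulfur; one five-membered aromatic ring with 1 hetero atom, one six-membered aromatic ring with 1 hetero atom) in place of a group of 9 heavy atoms (7 carbon, 1 nitrogen, 1 sulfur; one five-membered aromatic ring with 2 hetero atoms, one six-membered aromatic ring of carbon only), on an aromatic carbon.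

For the measured compounds named here, two measured steps bear on this. The step from compound 1 gave a number 0.25 higher from compound 1 to compound 2 (beyond the scatter), and replacing the same group by a sulfur- and nitrogen-containing bicycle gave a number 0.32 higher from compound 1 to compound 3 (beyond the scatter). Between the two larger groups themselves the step was a number 0.070 higher from compound 2 to compound 3 (within the scatter). Going by the values given here, no measured pair compares two bicycles that share sulfur and nitrogen but differ only in arrangement, so the closest guide is the small gap between compound 2 and compound 3.

Compound 4 is therefore expected to sit near compound 3, with a step of a number 0.040 lower from compound 3 to compound 4 (within the scatter) and no movement beyond the scatter. Compound 4 is estimated at 0.8, within a range from 0.66 to 0.92.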

Compound 4, hepatic extraction ratio: 0.72
Compound 4: the middle estimate sits 0.080 above what was measured; measured number inside the range.
By their numbers in this assay, from the lowest: compound 1; then compounds 4, 2 and 3 (each within the scatter of the next, the first and the last beyond it).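

In this assay, rearranging the same atoms into a different group on the aromatic carbon next to the ring oxygen was not a neutral exchange: it gave a number 0.12 lower from compound 3 to compound 4 (beyond the scatter), even though the heavy atoms and the counted hydrogen-bond donors and acceptors stayed the same, so at this position the arrangement of the group matters as well as its composition. Against the group made of carbon alone the step reads a number 0.050 lower from compound 2 to compound 4 (within the scatter), while against the group with nitrogen in both its rings it reads a number 0.20 higher from compound 1 to compound 4 (beyond the scatter), which shows that this third sulfur-containing arrangement still leaves the read-out well apart from the value of compound 1. Nothing available gives a reason for the shift between the two arrangements.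

The compounds shown leave open whether the shift follows the nitrogen entering the six-membered ring or the new placing of the sulfur in the five-membered ring, as the two change together here. They also leave open how a single ring such as pyridine or thiophene, or a bicycle carrying an amine or a carboxylic acid, would read in this assay at this same place.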